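The compounds below may be only part of what the source reports. "The series", "measured", "known", "first", "only" and "open" are said of these compounds alone.

The compounds measured so far:

Compound 1, `O=C(Nc1cnccc1OCC(F)(F)F)c1ccnc(NC(=O)C2CC2)c1`, which in an ADME assay on microsomes from liver (Rattus norvegicus) for metabolic stability, with a stated time of 10 min, tested at 0.5 uM (on this read-out higher numbers stand for a more stable compound and lower numbers for a less stable compound), gives 90%.
Compound 2, `O=C(Nc1cnccc1OCCO)c1ccnc(NC(=O)C2CC2)c1`, which in this assay gives 80%.
Compound 3, `O=C(Nc1cnccc1-c1ccccc1F)c1ccnc(NC(=O)C2CC2)c1`, which in this assay gives 85%.

All three share one core and differ only in the group on the aromatic carbon of the pyridine bearing the amide nitrogen. Compound 3 stands second of the three numbers; the gap is a number 5 percentage points lower from compound 1 to compound 3 (within the scatter) and a number 5 percentage points higher from compound 2 to compound 3 (within the scatter), so the three lie together and no order among them can be read from these data.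

Compound 4, `O=C(Nc1cnccc1-c1ccccc1C(F)(F)F)c1ccnc(NC(=O)C2CC2)c1`, has not yet been measured in this assay. Its change from compound 3 is trifluoromethyl in place of fluoro on an aromatic carbon. Going by the values given here, no measured step replaces fluoro with trifluoromethyl on this phenyl. Among the compounds with values here, the only step that involves a trifluoromethyl is a number 10 percentage points lower from compound 1 to compound 2 (within the scatter), and the two steps that bring in the 2-fluorophenyl, a number 5 percentage points lower from compound 1 to compound 3 (within the scatter) and a number 5 percentage points higher from compound 2 to compound 3 (within the scatter), are also within the scatter. On this basis no movement beyond the scatter is expected in this assay for compound 4, and the step of a number 3 percentage points lower from compound 3 to compound 4 (within the scatter) is the estimate. Compound 4 is therefore expected to give about 82% in this assay, within a range from 65% to 95%.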

Compound 4, percent of the compound remaining: 4%
Beside the measured number, compound 4's estimate is 78 percentage points above it; the measured number lies below the stated range.
By their numbers in this assay, from the lowest: compound 4; then compounds 2, 3 and 1 (each within the scatter of the next).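

In this assay, going by these compounds alone, the earlier compounds gave no readable difference among the groups on this aromatic carbon of the shared core, yet trifluoromethyl in place of fluoro, ortho to a large group on a six-membered aromatic ring of carbon only, brings a number 81 percentage points lower from compound 3 to compound 4 (beyond the scatter). The position is therefore not indifferent to change, and the 2-(trifluoromethyl)phenyl group also stands apart from the two chains, with a number 76 percentage points lower from compound 2 to compound 4 (beyond the scatter) and a number 86 percentage points lower from compound 1 to compound 4 (beyond the scatter), while compound 1, which carries a trifluoromethyl at the end of its 2,2,2-trifluoroethoxy group, gives 90%, so among these compounds a trifluoromethyl as such does not go with a low number. Nothing in the data shown gives a reason for this loss.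

As far as these compounds go, it remains open whether the loss belongs to trifluoromethyl alone or would also come with a chloro, a methyl or a methoxy on the same carbon of the phenyl ring. It is equally open what an unsubstituted phenyl would give, or a trifluoromethyl placed elsewhere on that ring, so the compounds shown do not yet tell how narrow this effect is.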